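The source may hold more compounds than are shown below. What is called first, only, known or untested is meant among the compounds shown, and "the series" means these compounds.

In a functional assay on LNCaP cells (Homo sapiens) for antiproliferative activity, read by propidium iodide staining, with a stated time of 96 h (a higher number here means a weaker inhibitor, a lower number a stronger inhibitor), compound 1 (`CC(O)(COc1ccc(C#N)cc1)C(=O)Nc1cccc(S(F)(F)(F)(F)F)c1`) gives 30000 nM, compound 2 (`CC(O)(COc1ccc(C#N)c(F)c1)C(=O)Nc1cccc(S(F)(F)(F)(F)F)c1`) gives 83700 nM and compound 3 (`CC(O)(CS(=O)(=O)c1ccc(S(F)(F)(F)(F)F)cc1)C(=O)Nc1ccc(S(F)(F)(F)(F)F)cc1`) gives 29200 nM. Compound 3 thus stands level with compound 1, while compound 2 lies clear of both with the higher number. Compound 4 (`CC(O)(CS(=O)(=O)c1ccc(F)cc1)C(=O)Nc1ccc(S(F)(F)(F)(F)F)cc1`) differs from compound 3 by a single change: one fluorine atom in place of a group of 6 heavy atoms (5 fluorine, 1 sulfur; no ring), on an aromatic carbon. For the measured compounds named here, only one measured step bears on this, a 2.8-fold higher number from compound 1 to compound 2 (0.45 log units; beyond the scatter), where a fluoro replaced hydrogen on an aromatic carbon. It replaced no larger group, so it is only a loose guide. Going by the values given here, a small rise in this assay, no larger than that step, is therefore expected and may stay within the scatter. The expected change is a 1.5-fold higher number from compound 3 to compound 4 (0.19 log units; within the scatter). For compound 4 the estimated value is 45000 nM, within an expected range of 15000 nM to 110000 nM.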

Compound 4, half-maximal inhibitory concentration: 18200 nM
Compound 4: middle estimate off by 2.5-fold (0.39 log units), on the high side, within the range that was stated.
By their numbers in this assay, from the lowest: compounds 4, 3 and 1 (each within the scatter of the next); then compound 2.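

In this assay, putting a fluoro in place of the group of 6 heavy atoms (5 fluorine, 1 sulfur) on this aromatic carbon gives a 1.6-fold lower number from compound 3 to compound 4 (0.21 log units; within the scatter). For the compounds shown here, this assay therefore does not separate the two groups here, although they differ greatly in size, and this is the first reading at this position. No evidence is available to explain this result.

The compounds shown leave open how hydrogen, an amine or a carboxylic acid on this aromatic carbon would read. They also leave open whether the same replacement would read alike on the core of compound 1.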